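The source may report more compounds than this note shows. Statements on the series, on what has been measured and on what is new or still open speak of the compounds shown alone.

Compound 1 `CC(C)[C@H](NC(=O)COc1cccc2ccccc12)C(=O)N[C@@H](CC(=O)O)C(=O)COc1cc(C(F)(F)F)n(C)n1` gives 46000 nM in a functional assay on Jurkat cells (Homo sapiens) for inhibition; a lower number here means a stronger inhibitor, a higher number a weaker inhibitor.
Compound 2 `CC(C)[C@H](NC(=O)COc1cccc2ccccc12)C(=O)N[C@@H](CC(=O)O)C(=O)CSC1=NCCS1` gives only a limit of the assay, > 200000 nM, in this assay.
Compound 3 `CC(C)[C@H](NC(=O)COc1cccc2ccccc12)C(=O)N[C@@H](CC(=O)O)C(=O)COc1nc2ccccc2[nH]1` also gives only a limit of the assay, > 200000 nM, in this assay.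

Compound 3 therefore stands at the weak end of what has been measured, and it is not alone there: the limit of > 200000 nM in this assay, at which 2 of the 3 values shown sit. Among the compounds with values here, the one readable step into compound 3 is an at least 4.3-fold higher number from compound 1 to compound 3 (0.63 log units; beyond the scatter), a swap of the aromatic group on the oxygen. The other step, a step that the two limits leave unreadable from compound 2 to compound 3, cannot be sized, as both ends are limits.

Compound 4 `Cc1cc(OCC(=O)[C@H](CC(=O)O)NC(=O)[C@@H](NC(=O)COc2cccc3ccccc23)C(C)C)nc(C)n1` carries a further swap at the same oxygen: 2,6-dimethylpyrimidin-4-yl in place of 1H-benzimidazol-2-yl on an oxygen on a saturated carbon. Within the data shown here, no measured step shows a pyrimidinyl group at this place, and the only aromatic swap measured ended in a limit. The expectation is that compound 4 lands somewhere between the number of compound 1 and the limit, with an at least 1.6-fold lower number from compound 3 to compound 4 (0.22 log units; that floor lies within the scatter) as the expected step. Compound 4 is estimated at 120000 nM, within a range from 40000 nM to 300000 nM.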

Compound 4, half-maximal inhibitory concentration: > 200000 nM
Compound 4: no number, only a limit; the forecaster's own chance of this, stated with the estimate: 45%; at least 1.6-fold (0.22 log units) between middle value and limit.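

Compound 4 also gives only a limit in this assay, and it joins a growing group: the limit of > 200000 nM in this assay, at which 3 of the 4 values shown sit.

Putting 2,6-dimethylpyrimidin-4-yl in place of 1-methyl-5-(trifluoromethyl)-1H-pyrazol-3-yl on this oxygen gives an at least 4.3-fold higher number from compound 1 to compound 4 (0.63 log units; beyond the scatter). Among the aromatic groups shown on this oxygen, only the group of compound 1 gives a number, while both the single ring of compound 4 and the two rings of compound 3 end at the limit, and the steps among compound 2, compound 3 and compound 4 cannot be read.

On these data alone, the order of those three compounds therefore stays open. Also open, as far as these compounds go, is whether a plain phenyl ring on this oxygen would give a readable number, and whether 1-methyl-1H-pyrazol-3-yl, lacking the trifluoromethyl group, would match compound 1.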